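The source may report more compounds than this note shows. Statements on the series, on what has been measured and on what is new or still open speak of the compounds shown alone.

Measured compounds:
- compound 1 `CC(=O)/C=C1\C[C@H]2SC(C)(C)[C@H](C(=O)OC(c3ccccc3)c3ccccc3)N2C1=O`: in a functional assay on OE19 cells (Homo sapiens) for cytotoxicity, read by MTT assay, with a stated time of 48 h (on this read-out higher numbers stand for weaker inhibition and lower numbers for stronger inhibition), compound 1 gives > 100000 nM, a limit of the assay.
- compound 2 `CC1(C)[C@H](C(=O)OC(c2ccccc2)c2ccccc2)N2C(=O)/C(=C/C(=O)c3ccccc3)[C@H]2S1(=O)=O`: compound 2 gives 53100 nM.
- compound 3 `CC1(C)S[C@@H]2/C(=C\C(=O)c3ccc([N+](=O)[O-])cc3)C(=O)N2[C@H]1C(=O)OC(c1ccccc1)c1ccccc1`: compound 3 gives 44100 nM.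

Compound 3 holds the lower of the two numbers, but compound 2 sits within the usual scatter of it, so no order between the two can be claimed. For compound 1 only the limit is shown (the limit of > 100000 nM in this assay, at which 1 of the 3 values shown sits). Compound 4 `CC1(C)S[C@@H]2/C(=C\C(=O)c3ccc(Cl)cc3)C(=O)N2[C@H]1C(=O)OC(c1ccccc1)c1ccccc1` differs from compound 3 by chloro in place of nitro on an aromatic carbon. Among the measured compounds shown here, no measured pair shows this change, so no step can be drawn from the series itself. The step from compound 3 to compound 4 is expected to be small, a 1.1-fold higher number from compound 3 to compound 4 (0.05 log units; within the scatter), with no change beyond the scatter in either direction. Compound 4 is estimated at 50000 nM, within 20000 nM to 110000 nM.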

Compound 4, half-maximal inhibitory concentration: 14600 nM
For compound 4 the middle estimate is 3.4-fold (0.53 log units) above the measured one, outside the stated range (below it).
By their numbers in this assay, from the lowest: compound 4; then compounds 3 and 2 (each within the scatter of the next). At a limit, above all of these: compound 1.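

In this assay, among the compounds shown here, chloro in place of nitro on an aromatic carbon gives a 3.0-fold lower number from compound 3 to compound 4 (0.48 log units; beyond the scatter) and is the only change that can be read as a step. The group on this carbon, para to a large group, therefore moves the number, though modestly. Nothing measured here bears on why it does so.

Only nitro and chloro are shown at this position, so no trend across groups can be drawn. As far as these compounds go, whether an amine, methoxy or a carboxylic acid on the same carbon would lower the number further remains open.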